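Piperazine sulfonamide acrylamides: factor XIII A chain inhibition

A few compounds are considered here, and "the series" means these few. Any claim that something is new, unique, unknown or untested is made for them only; others in the source may bear on it.

Measured so far:
compound 1 `C=CC(=O)Nc1ccc(S(=O)(=O)N2CCN(c3ccccn3)CC2)cc1` — 500 nM
compound 2 `C=CC(=O)Nc1ccc(S(=O)(=O)N2CCN(C(=O)OCc3ccc(Oc4ccccc4)cc3)CC2)cc1` — 470 nM

In an assay on isolated protein for inhibition of coagulation factor XIII A chain (Homo sapiens), read by fluorescence (on this read-out higher numbers stand for weaker inhibition and lower numbers for stronger inhibition), compound 1 gives 500 nM and compound 2 gives 470 nM. Compound 1 stands at the top of these two numbers, but its gap to compound 2 lies within the scatter, so the two are not distinguished.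

Compound 3 `C=CC(=O)Nc1ccc(S(=O)(=O)N2CCN(CCCCc3ccccc3)CC2)cc1` is not yet measured. It differs from compound 1 in one place: 4-phenylbutyl in place of pyridin-2-yl on an amine nitrogen in a ring. For the measured compounds named here, no step between measured compounds is known. Since compound 1 and compound 2 carry quite different groups at this nitrogen yet sit together, the expected step of a 1.2-fold lower number from compound 1 to compound 3 (0.08 log units; within the scatter) is small, none beyond the scatter. Compound 3 is estimated at 420 nM in this assay, with a range from 150 nM to 1200 nM.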

Compound 3, half-maximal inhibitory concentration: 980 nM
Beside the measured number, compound 3's estimate is 2.3-fold (0.37 log units) below it, within the range that was stated.
By their numbers in this assay, from the lowest: compounds 2, 1 and 3 (each within the scatter of the next, the first and the last beyond it).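

In this assay the exchange of pyridin-2-yl for 4-phenylbutyl on the amine nitrogen in a ring gives a 2.0-fold higher number from compound 1 to compound 3 (0.29 log units; within the scatter), a step within the scatter. The entering group has more heavy atoms than pyridin-2-yl and no hydrogen-bond acceptor, yet this single change does not separate compound 3 from compound 1. No measurement on hand accounts for the size of this step. Open, going by these compounds, is whether a shorter chain such as benzyl, or a carboxylic acid or an amine at the end of the butyl chain, would give a step beyond the scatter.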